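The source may report more compounds than this note shows. Statements on the series, on what has been measured and on what is new or still open speak of the compounds shown alone.

In a functional assay on CCRF-CEM cells (Homo sapiens) for antiproliferative activity, read by cell counting, with a stated time of 2 days (a lower number here means a stronger inhibitor, a higher number a weaker inhibitor), compound 1 (`COc1cc(C(=O)c2sc(N3CCCC3)nc2N)cc(OC)c1OC`) gives 320 nM, while compound 2 (`COc1ccc(C(=O)c2sc(N3CCCC3)nc2N)cc1OC`) gives 19000 nM, the higher of the two numbers and so the weaker result. Compound 3 (`COc1ccc(C(=O)c2sc(N3CCCC3)nc2N)cc1`) is the next structure in view. Its change from compound 2 is hydrogen in place of methoxy on an aromatic carbon, ortho to a methoxy group and meta to a large group. For the measured compounds named here, only one measured step bears on this change, and it is of the same kind: a 59-fold higher number from compound 1 to compound 2 (1.77 log units; beyond the scatter), which is large and beyond the scatter. This single precedent points to a higher number in this assay, but it cannot fix the size of a second such step, so a smaller rise is assumed. The expected change is a 2.4-fold higher number from compound 2 to compound 3 (0.37 log units; beyond the scatter). For compound 3 the estimated value is 45000 nM, with an expected range of 15000 nM to 150000 nM.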

Compound 3, half-maximal inhibitory concentration: > 200000 nM
Compound 3 ended at the assay's limit; the forecaster's own chance of this, stated with the estimate: 35%; middle value at least 4.4-fold (0.64 log units) from the limit.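

The second replacement of methoxy by hydrogen gives an at least 10-fold higher number from compound 2 to compound 3 (1.02 log units; beyond the scatter) in this assay, so the rise seen earlier is not confined to a single methoxy group on this aromatic ring. Across these three compounds, each loss of a methoxy group raises the number beyond the scatter, but whether this second step is larger or smaller than a 59-fold higher number from compound 1 to compound 2 (1.77 log units; beyond the scatter) cannot be read. Compound 3 stands at a limit of the assay and not at a number: the limit of > 200000 nM in this assay, at which 1 of the 3 values shown sits.

The compounds shown leave open whether a hydroxyl, an ethoxy or a chlorine on this aromatic carbon would keep the number nearer that of compound 2, at 19000 nM. For the compounds shown here, they also leave open what hydrogen in place of the one remaining methoxy group would give.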